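This account rests on a few compounds, and the source may have more. Where it says the series, first, only, none or still open, it means among the compounds named here.

Series notes. Compound 1 `CC(=O)OCC(C)(C)NC(=O)N(CCC1CCN(Cc2ccc(C)cc2)CC1)Cc1ccc(-c2ccc(F)cc2)cc1` and compound 2 `CC(=O)OCC(C)(C)NC(=O)N(CCC1CCN(Cc2ccc(C)cc2)CC1)Cc1ccc(-c2ccccc2)cc1` share one core and differ only in a fluoro on an aromatic carbon against hydrogen. In an in vitro functional assay on HEK293 cells for antagonist activity at melanin-concentrating hormone receptor 1 (Homo sapiens), read by GTPgammaS binding, with a stated time of 45 min (on this read-out higher numbers stand for higher potency (the scale is a negative logarithm) and lower numbers for lower potency), compound 1 gives 6.39, and in this assay compound 2 gives 6.44. The step of a number 0.05 log units higher from compound 1 to compound 2 (within the scatter) is the only one measured so far, and it lies within the scatter: the two numbers do not separate, so compound 2 stands alongside compound 1 rather than apart from it.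

Compound 3 `Cc1ccc(CN2CCC(CCN(Cc3ccc(-c4ccccc4)cc3)C(=O)NC(C)(C)CO)CC2)cc1` is not yet measured. Against compound 2 the difference is hydrogen in place of acetyl on an oxygen on a saturated carbon. For the measured compounds named here, no measured step bears on this change: the one step in hand, a number 0.05 log units higher from compound 1 to compound 2 (within the scatter), concerns hydrogen in place of fluoro on an aromatic carbon and says nothing about acetoxy to hydroxy. Going by the values given here, with no step of this kind measured, the expectation for this assay rests on the number of compound 2 with a wide allowance either way, and the expected step is a number 0.14 log units lower from compound 2 to compound 3 (within the scatter). Compound 3 is expected to give 6.3, within a range from 5.6 to 7.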

Compound 3, negative logarithm of the antagonist equilibrium constant: 6.2
Estimate against measurement, compound 3: 0.10 log units above; measured number inside the range.
By their numbers in this assay, from the lowest: compounds 3, 1 and 2 (each within the scatter of the next).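

For the compounds shown here, compound 3 gives the first reading at this position: in this assay, hydrogen in place of acetyl on an oxygen on a saturated carbon gives a number 0.24 log units lower from compound 2 to compound 3 (within the scatter). Until now the series spoke only to fluoro against hydrogen on an aromatic carbon, whereas this step shows that the acetyl, with its 3 heavy atoms and its double bond outside aromatic rings, can leave this oxygen without the number moving beyond the scatter, so that 1-(acetoxymethyl)-1-methylethyl and 1-(hydroxymethyl)-1-methylethyl are not told apart on this read-out. No supporting measurement accompanies this result to say what lies behind the two numbers standing together.

The compounds shown carry only an acetoxy or a hydroxy at this place, so it remains open whether an amine, a carboxylic acid, a methoxy or a longer chain ending in hydroxy would stay alongside compound 2 and compound 3 or move clear of them. Also open, going by these compounds, is whether the fluoro of compound 1 and the hydroxy of compound 3, taken together on the shared core, would stay within the same scatter.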